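Removing a Methyl from an Oxygen on the Aryl Ring

The compounds below may be only part of what the source reports. "The series", "measured", "known", "first", "only" and "open" are said of these compounds alone.

Compound 1, `Cc1cc(O)cc(-c2nn(CC#N)cc2-c2ccnc(-c3ccc(Oc4ccccc4)cc3)c2)c1`: 75200 nM in a functional assay on SF-295 cells (Homo sapiens) for inhibition, read by sulforhodamine B assay, with a stated time of 48 h; on this read-out higher numbers stand for lower toxicity in this test and lower numbers for higher toxicity in this test.
Compound 2, `COc1cc(C)cc(-c2nn(CC#N)cc2-c2ccnc(-c3ccc(N(C)C)cc3)c2)c1`: > 100000 nM, a limit only.

Compound 2 stands at the edge of what this assay reports: its result is a limit, (the limit of > 100000 nM in this assay, at which 1 of the 2 values shown sits), not a number. Compound 3, `Cc1cc(O)cc(-c2nn(CC#N)cc2-c2ccnc(-c3ccc(N(C)C)cc3)c2)c1`, differs from compound 2 by one change, (hydrogen in place of methyl on an oxygen on an aromatic ring). For the measured compounds named here, no measured pair shows this change. Compound 1 carries the same hydroxy group and gives only 75200 nM, a weak result, so the step of an at least 1.1-fold lower number from compound 2 to compound 3 (0.04 log units; that floor lies within the scatter) is expected to stay within the usual scatter. Compound 3 is therefore estimated at 90000 nM, ranging from 40000 nM to 200000 nM, and may again return as a limit.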

Compound 3, concentration lethal to 50% of the cells: 84100 nM
Beside the measured number, compound 3's estimate is 1.1-fold (0.03 log units) above it, and the stated range covers the measured number.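

In this assay, on these data alone, going from methoxy to hydroxy gives an at least 1.1-fold lower number from compound 2 to compound 3 (0.07 log units; that floor lies within the scatter), so this change on the oxygen has only a floor for its size, and its true size stays unknown. With the hydroxy group held in place, dimethylamino in place of phenoxy gives a 1.1-fold higher number from compound 1 to compound 3 (0.05 log units; within the scatter), so that swap shows no separation beyond the scatter. Compound 2 remains a limit and not a number: the limit of > 100000 nM in this assay, at which 1 of the 3 values shown sits.

The compounds shown leave open how an ethoxy group, with its longer chain on that oxygen, or an amine in place of the hydroxy group would read in this test.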